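Same Amide Change, Second Occurrence, Expected Step

This account rests on a few compounds, and the source may have more. Where it says the series, first, only, none or still open, it means among the compounds named here.

Of the compounds shown here, three have been measured in a functional assay (QGY7701 cells, Homo sapiens) for inhibition, read by MTT assay, with a stated time of 48 h; a higher number here means a weaker inhibitor, a lower number a stronger inhibitor. Compound 1 `COc1ccc2c(=O)c(/C=C/C(=O)NCc3ccc(C)cc3)coc2c1` gives 10200 nM. Compound 2 `Cc1ccccc1NC(=O)/C=C/c1coc2cc(O)ccc2c1=O` gives 9320 nM, and compound 3 `COc1ccc2c(=O)c(/C=C/C(=O)Nc3ccccc3C)coc2c1` gives 22500 nM. Compound 2 has the lowest of the three numbers, but its gap to compound 1 lies within the scatter, so those two cannot be ordered; only compound 3 stands clearly apart from compound 2.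

Two single changes connect the measured compounds. From compound 3 to compound 1 the change is 4-methylbenzyl in place of 2-methylphenyl on an amide-type nitrogen, and it brought a 2.2-fold lower number from compound 3 to compound 1 (0.34 log units; beyond the scatter). From compound 3 to compound 2 the change is hydrogen in place of methyl on an oxygen on an aromatic ring; read the other way, it gave a 2.4-fold higher number from compound 2 to compound 3 (0.38 log units; beyond the scatter).

Compound 4 `Cc1ccc(CNC(=O)/C=C/c2coc3cc(O)ccc3c2=O)cc1` has not yet been measured in this assay. It differs from compound 2 by 4-methylbenzyl in place of 2-methylphenyl on an amide-type nitrogen, which is the same change as that from compound 3 to compound 1, at a place described in the same words. How the cores of the two pairs differ is told by hydrogen in place of methyl on an oxygen on an aromatic ring. This change has occurred once before among the compounds shown, where it made the step of a 2.2-fold lower number from compound 3 to compound 1 (0.34 log units; beyond the scatter); the expectation for compound 4 rests on that single precedent and on nothing else. Compound 4 is expected to move by a 1.9-fold lower number from compound 2 to compound 4 (0.29 log units; within the scatter). Compound 4 is therefore estimated at 4800 nM, with an expected range from 2400 nM to 11000 nM.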

Compound 4, half-maximal inhibitory concentration: 24900 nM
The estimate for compound 4 lay 5.2-fold (0.71 log units) below the measured number, and the stated range ends below it.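

In this assay, 4-methylbenzyl in place of 2-methylphenyl on the amide-type nitrogen gave a 2.7-fold higher number from compound 2 to compound 4 (0.43 log units; beyond the scatter), a step opposite in direction to the one seen earlier with methyl on the oxygen on the aromatic ring: the same change on two cores in this assay, a 2.2-fold lower number (0.34 log units; beyond the scatter) from compound 3 to compound 1 and a 2.7-fold higher number (0.43 log units; beyond the scatter) from compound 2 to compound 4, 5.9-fold (0.77 log units) apart, beyond the scatter of two such steps The companion change, hydrogen in place of methyl on that oxygen, also failed to carry over, giving a 2.4-fold higher number from compound 1 to compound 4 (0.39 log units; beyond the scatter), whereas with the 2-methylphenyl amide the compound bearing hydrogen had the lower number: the same change on two cores in this assay, a 2.4-fold higher number (0.38 log units; beyond the scatter) from compound 2 to compound 3 and a 2.4-fold lower number (0.39 log units; beyond the scatter) from compound 4 to compound 1, 5.9-fold (0.77 log units) apart, beyond the scatter of two such steps Across these four compounds, the effect of either change therefore depends on the other, so a step seen on one core could not be carried to the other, although the data do not show why the direction reverses or whether this holds beyond these two pairs.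

The compounds shown leave open whether the reversal follows the added carbon or the place of the methyl, which 2-methylbenzyl and 4-methylphenyl amides could separate. They also leave open whether an unsubstituted benzyl amide or a longer chain such as 2-phenylethyl on the nitrogen would behave like 4-methylbenzyl on either core.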